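The compounds below may be only part of what the source reports. "The series", "measured", "known", "first", "only" and "open" are said of these compounds alone.

Compound 2 `COc1cc(-c2nn(-c3cccc(NC(=O)c4cccc(C(F)(F)F)c4)c3)cc2-c2ccncc2)ccc1Cl` gives 3240 nM in a functional assay on TK-10 cells (Homo sapiens) for inhibition, read by sulforhodamine B assay, with a stated time of 48 h (a lower number here means a stronger inhibitor of growth, a higher number a weaker inhibitor of growth), the highest number among the three measured compounds. Compound 1 `COc1cc(-c2nn(-c3cccc(NC(=O)Nc4cc(C(F)(F)F)cc(C(F)(F)F)c4)c3)cc2-c2ccncc2)ccc1Cl` gives 894 nM in this assay, and compound 3 `O=C(Nc1cccc(-n2cc(-c3ccncc3)c(-c3ccc(Cl)c(O)c3)n2)c1)Nc1cc(C(F)(F)F)cc(C(F)(F)F)c1` gives 959 nM in this assay. Compound 4 `COc1cc(-c2nn(-c3cccc(NC(=O)Nc4ccc(Cl)c(C(F)(F)F)c4)c3)cc2-c2ccncc2)ccc1Cl` differs from compound 2 by (4-chloro-3-(trifluoromethyl)phenyl)amino in place of 3-(trifluoromethyl)phenyl on a carbonyl carbon. Among the measured compounds shown here, no measured step covers this change directly: the only measured step, a 1.1-fold higher number from compound 1 to compound 3 (0.03 log units; within the scatter), concerns another part of the molecule. Compounds 1 and 3, which like compound 4 carry an amino group on the carbonyl carbon, both show clearly lower numbers than compound 2. Compound 4 is therefore expected to give a lower number, a step of a 3.2-fold lower number from compound 2 to compound 4 (0.51 log units; beyond the scatter) in this assay. The estimate for compound 4 in this assay is 1000 nM, with a range from 400 nM to 3000 nM.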

Compound 4, concentration for 50% growth inhibition: 1520 nM
Compound 4: the middle estimate sits 1.5-fold (0.18 log units) below what was measured; the measured number falls inside the stated range.
By their numbers in this assay, from the lowest: compounds 1, 3 and 4 (each within the scatter of the next); then compound 2.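

Among the compounds shown here, the step at the carbonyl carbon is the first measured change at this position: in this assay, (4-chloro-3-(trifluoromethyl)phenyl)amino in place of 3-(trifluoromethyl)phenyl gives a 2.1-fold lower number from compound 2 to compound 4 (0.33 log units; beyond the scatter), a modest change. The earlier step concerned only the methyl on an oxygen elsewhere in the molecule. No measurement shown offers a reason for this step.

The change adds the amino group and the chlorine together, so their shares in the step remain unseparated. From the compounds shown here alone, it also stays open how a methylene or an oxygen in place of the amino group on the carbonyl carbon would read.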